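Cytotoxicity notes: chloro in place of 2-methoxyethoxy

The source may report more compounds than this note shows. Statements on the series, on what has been measured and on what is new or still open speak of the compounds shown alone.

Measured so far:
compound 1 `CCCCOc1ccc(-c2nc3ncccn3c2NC(C)C)cc1`: 68000 nM
compound 2 `Nc1nc2ncccn2c1-c1ccc(Br)cc1`: > 100000 nM
compound 3 `COCCOc1ccc(-c2nc3ncccn3c2NC2CCCCC2)cc1`: > 100000 nM

The three compounds share one core and differ in the group on the aryl ring and in the amine substituent. In a toxicity assay on A549 cells (Homo sapiens) for cytotoxicity, read by luminescence and CellTiter-Glo, with a stated time of 48 h (a lower number here means that less compound is tolerated, a higher number that more compound is tolerated), compound 1 gives 68000 nM. For compound 2 the value of > 100000 nM is a limit of the assay and not a number. For compound 3 the value of > 100000 nM is likewise a limit of the assay and not a number. Where compound 3 stands is therefore given only by the limit of > 100000 nM in this assay, at which 2 of the 3 values shown sit; no measured step within the series is available.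

Compound 4 `Clc1ccc(-c2nc3ncccn3c2NC2CCCCC2)cc1` keeps the cyclohexylamine of compound 3 and carries chloro in place of 2-methoxyethoxy on an aromatic carbon. Among the measured compounds shown here, no pair of measured compounds reproduces this change, so the size of the step has to be estimated. Compound 2, whose aryl ring carries a halogen, also sits at a limit in this assay, and compound 1 with its alkoxy chain lies close by. The step from compound 3 to compound 4 is expected to be an at least 1.1-fold lower number from compound 3 to compound 4 (0.04 log units; that floor lies within the scatter), that is, none beyond the scatter. Compound 4 is accordingly expected to give about 90000 nM in this assay, within a range of 40000 nM to 200000 nM, with a fair chance that only a limit is reported.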

Compound 4, half-maximal cytotoxic concentration: > 100000 nM
Compound 4: no number, only a limit; the forecaster's own chance of this, stated with the estimate: 55%; middle value at least 1.1-fold (0.04 log units) away from the limit.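

Compound 3 and compound 4 both stand at a limit of the assay and not at a number, so no step between them can be read: the limit of > 100000 nM in this assay, at which 3 of the 4 values shown sit.

What the compounds shown leave open is whether chloro in place of 2-methoxyethoxy changes the half-maximal cytotoxic concentration in this assay at all, and in which direction.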